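A few compounds are considered here, and "the series" means these few. Any claim that something is new, unique, unknown or untested is made for them only; others in the source may bear on it.

Working notes on the series. In a functional assay on HT-29 cells (Homo sapiens) for cytotoxicity, read by MTT assay, with a stated time of 72 h (a lower number here means a stronger inhibitor, a higher number a weaker inhibitor), compound 1 `O=C(Nc1ccc(-n2ncc3c(C(F)(F)F)cccc32)cc1)Nc1ccc(Cl)c(C(F)(F)F)c1` gives 2900 nM, compound 2 `O=C(Nc1ccc(-n2ncc3c(Cl)cccc32)cc1)Nc1ccc(Cl)c(C(F)(F)F)c1` gives 4600 nM, and compound 3 `O=C(Nc1ccc(-n2ncc3ccccc32)cc1)Nc1ccc(Cl)c(C(F)(F)F)c1` gives 18200 nM, the highest of the three numbers and so the weakest of the measured set. The steps of a 6.3-fold higher number from compound 1 to compound 3 (0.80 log units; beyond the scatter) and a 4.0-fold higher number from compound 2 to compound 3 (0.60 log units; beyond the scatter) both describe the loss of a substituent from the shared core, which is what places compound 3 at this end. Compound 4 `O=C(Nc1ccc(-n2ncc3cccnc32)cc1)Nc1ccc(Cl)c(C(F)(F)F)c1` differs from compound 3 by a group of 9 heavy atoms (6 carbon, 3 nitrogen; one five-membered aromatic ring with 2 hetero atoms, one six-membered aromatic ring with 1 hetero atom) in place of a group of 9 heavy atoms (7 carbon, 2 nitrogen; one five-membered aromatic ring with 2 hetero atoms, one six-membered aromatic ring of carbon only), on an aromatic carbon. Going by the values given here, none of the measured steps touches this kind of exchange, so the data give no direction for it; a step no larger than the scatter is expected, a 1.0-fold lower number from compound 3 to compound 4 (0.00 log units; within the scatter). Compound 4 is therefore estimated at 18000 nM, with a range of 6000 nM to 55000 nM.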

Compound 4, half-maximal inhibitory concentration: > 32000 nM
Compound 4: only a limit was reported (the forecaster's own chance of this, stated with the estimate: 15%); at least 1.7-fold (0.24 log units) between middle value and limit.
By their numbers in this assay, from the lowest: compounds 1 and 2 (each within the scatter of the next); then compound 3. At a limit, above all of these: compound 4.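

In this assay compound 4 is reported only as a limit: the limit of > 32000 nM in this assay, at which 1 of the 4 values shown sits. Placing a hetero atom in the six-membered ring gives an at least 1.7-fold higher number from compound 3 to compound 4 (0.24 log units; that floor lies within the scatter), so this floor shows no gain over the 1H-indazol-1-yl group and does not establish a loss. The step of an at least 6.9-fold higher number from compound 2 to compound 4 (0.84 log units; beyond the scatter) shows that this exchange does not recover the level reached with the chloro group.

Going by these compounds, the true size of both steps remains open. So does the effect of a methoxy group or an amine in place of that chloro group.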